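Compound 1 loses one benzyl group

The source may hold more compounds than are shown below. What is called first, only, known or untested is meant among the compounds shown, and "the series" means these compounds.

Among the compounds with values here, in a physicochemical assay for inhibition, read by spectrophotometry, with a stated time of 10 min (a higher number here means a weaker inhibitor, a lower number a stronger inhibitor), compound 1 (`Nc1nc(N)c2cc(N(Cc3ccc(OC(F)(F)F)cc3)Cc3ccc(OC(F)(F)F)cc3)ccc2n1`) gives 33900 nM and holds the higher of the two numbers so far. Compound 2 (`COc1ccc(CNc2ccc3nc(NC(C)=O)nc(NC(C)=O)c3c2)cc1`) gives 7040 nM and the gap between them lies beyond the scatter. Compound 3 (`Nc1nc(N)c2cc(NCc3ccc(OC(F)(F)F)cc3)ccc2n1`) has no reading yet. It differs from compound 1 by hydrogen in place of 4-(trifluoromethoxy)benzyl on a nitrogen on an aromatic ring with hydrogen in place of 4-(trifluoromethoxy)benzyl on a nitrogen on an aromatic ring. Within the data shown here, no measured step covers this change, so the expectation is loose. In this assay a clear drop beyond the scatter is expected, toward a stronger inhibitor, with an 11-fold lower number from compound 1 to compound 3 (1.05 log units; beyond the scatter) as the estimated step. Compound 3 is expected at 3000 nM with 300 nM to 25000 nM as the estimated range.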

Compound 3, half-maximal inhibitory concentration: 4750 nM
Compound 3: middle estimate off by 1.6-fold (0.20 log units), on the low side; the range from low to high includes it.
By their numbers in this assay, from the lowest: compounds 3 and 2 (each within the scatter of the next); then compound 1.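

In this assay, removing one 4-(trifluoromethoxy)benzyl from the nitrogen on an aromatic ring gives a 7.1-fold lower number from compound 1 to compound 3 (0.85 log units; beyond the scatter). Within the data shown here, this is the first measured step at this position. Among these compounds, the second 4-(trifluoromethoxy)benzyl is therefore not required for inhibition at this nitrogen, and the compound carrying only one of these groups is the stronger inhibitor of this pair.

Still open, as far as these compounds go, is whether the remaining 4-(trifluoromethoxy)benzyl can be replaced by a methyl, an unsubstituted benzyl or a longer chain carrying an amine or carboxylic acid. No available evidence bears on the reason for this step.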